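Swapping one chloro for hydrogen in compound 2

The source may hold more compounds than are shown below. What is called first, only, known or untested is meant among the compounds shown, and "the series" means these compounds.

Values so far in an ADME assay on HEK293 cells (Homo sapiens) for cytotoxicity, read by reporter gene assay and resazurin assay, with a stated time of 48 h (a lower number here means that less compound is tolerated, a higher number that more compound is tolerated), are:
Compound 1 `COc1ccccc1C(=O)Nc1ccc(Sc2nc3ccccc3s2)cc1` gives > 100000 nM (a limit of the assay)
Compound 2 `O=C(Nc1ccc(Sc2nc3ccccc3s2)c(Cl)c1)c1cc(Br)ccc1O` gives 45000 nM (a measured number)

For the measured compounds named here, compound 2 holds the only actual number so far, and its 45000 nM is the anchor for what follows. Compound 1 gives > 100000 nM and that is a limit, not a number.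

Compound 3 `O=C(Nc1ccc(Sc2nc3ccccc3s2)cc1)c1cc(Br)ccc1O` has not been measured yet. It differs from compound 2 in one place (hydrogen in place of chloro on an aromatic carbon) with hydrogen in place of chloro on an aromatic carbon, ortho to a large group and meta to a large group.

Going by the values given here, no measured step shows what this swap does in this assay so no step beyond the usual scatter is expected, with only a slight lean towards more compound tolerated. That lean rests on compound 1 and its limit of > 100000 nM alone, so it is weak. The expected change is a 1.3-fold higher number from compound 2 to compound 3 (0.12 log units; within the scatter) and it should stay small. For compound 3 the estimate is 60000 nM with an expected range from 25000 nM to 100000 nM and a fair chance that it turns out to be only a limit.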

Compound 3, half-maximal cytotoxic concentration: 42000 nM
For compound 3 the middle estimate is 1.4-fold (0.15 log units) above the measured one; the measured number falls inside the stated range.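

In this assay, hydrogen in place of chloro on this aromatic carbon, ortho to a large group and meta to a large group, gives a 1.1-fold lower number from compound 2 to compound 3 (0.03 log units; within the scatter) and leaves compound 2 and compound 3 indistinguishable, so the chloro makes no visible difference to the tolerated concentration here. The other comparison, 5-bromo-2-hydroxyphenyl in place of 2-methoxyphenyl on a carbonyl carbon, gives an at least 2.3-fold lower number from compound 1 to compound 3 (0.37 log units; beyond the scatter) and is the only step of the two that lies beyond the scatter, so among these three compounds the group on the carbonyl carbon is where a difference shows. Compound 1 gives > 100000 nM, which is a limit and not a number, so that step has a floor but no known size: the limit of > 100000 nM in this assay, at which 1 of the 3 values shown sits.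

Only chloro and hydrogen appear on that aromatic carbon, so the effect of an amine or a carboxylic acid there remains an open question. The step from compound 1 also swaps the whole aryl group at once, which leaves the separate shares of the bromo and the hydroxy group unresolved.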